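The source may hold more compounds than are shown below. What is called first, only, known or untested is meant among the compounds shown, and "the series" means these compounds.

Compound 1 `Cc1ccc(NC(=O)CCCCc2cn(Cc3ccc4oc(-c5ccc(Cl)cc5)cc(=O)c4c3)nn2)cc1` gives 32900 nM in an assay on isolated protein for inhibition of Amine oxidase [flavin-containing] B (Homo sapiens), read by fluorescence and spectrophotometry; a lower number here means a stronger inhibitor, a higher number a weaker inhibitor. Compound 2 `Cc1ccc(C(=O)NCc2cn(Cc3ccc4oc(-c5ccc(Cl)cc5)cc(=O)c4c3)nn2)cc1` gives 32900 nM in this assay. Compound 3 `O=C(CCc1cn(Cc2ccc3oc(-c4ccc(Cl)cc4)cc(=O)c3c2)nn1)Nc1ccc(Cl)cc1` gives 32900 nM in this assay.

On these numbers compound 3 stands level with compounds 1 and 2: the step of no change at the digits printed from compound 1 to compound 3 (within the scatter) and the step of no change at the digits printed from compound 2 to compound 3 (within the scatter) both sit within the scatter. Compound 4 `Cc1ccc(NC(=O)CCc2cn(Cc3ccc4oc(-c5ccc(Cl)cc5)cc(=O)c4c3)nn2)cc1` is made from compound 3 by methyl in place of chloro on an aromatic carbon. The step from compound 1 to compound 3 bears on this: it swaps a 4-methylphenyl-bearing amide for a 4-chlorophenyl-bearing one, together with a change in chain length, and moved nothing. Going by the values given here, no step here moves this assay beyond the scatter, so a change of the expected size no change at the digits printed from compound 3 to compound 4 (within the scatter) is essentially none. Compound 4 is therefore expected at 32900 nM, between 15000 nM and 70000 nM.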

Compound 4, half-maximal inhibitory concentration: 32900 nM
Compound 4: middle estimate and measured number agree at the digits printed, within the range that was stated.
By their numbers in this assay, from the lowest: compounds 1, 2, 3 and 4 (each within the scatter of the next).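

In this assay, methyl in place of chloro on the aromatic carbon para to a large group gives no change at the digits printed from compound 3 to compound 4 (within the scatter) with the rest of the structure held fixed, which isolates a change that the step from compound 1 to compound 3 had mixed with a different chain. With the 4-methylphenyl group now shared, ((4-methylphenyl)carbamoyl)methyl in place of ((4-methylphenyl)carbonyl)amino gives no change at the digits printed from compound 2 to compound 4 (within the scatter) and the change of group on the saturated chain carbon gives no change at the digits printed from compound 1 to compound 4 (within the scatter) as well. No measured evidence accounts for these results. On these data alone, whether an amine or a carboxylic acid at this para position would shift the value in this assay remains open.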